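Methoxy step from compound 2 to compound 3: growth inhibition

The source may report more compounds than this note shows. Statements on the series, on what has been measured and on what is new or still open speak of the compounds shown alone.

Measured compounds:
compound 1 `COc1ccc(/C=C/C2CC(=O)C=CO2)cc1` — 192 uM
compound 2 `O=c1ccoc(/C=C/c2ccccc2)c1` — 410 uM

In a functional assay on 786-0 cells (Homo sapiens) for inhibition, read by sulforhodamine B assay, with a stated time of 48 h (a lower number here means a stronger inhibitor of growth, a higher number a weaker inhibitor of growth), compound 1 gives 192 uM and compound 2 gives 410 uM. Compound 2 thus stands with the higher of the two numbers, and its gap to compound 1 lies beyond the scatter; the two compounds differ in more than one place, however, so no single step can be read from that pair.

Compound 3 `COc1ccc(/C=C/c2cc(=O)cco2)cc1` is compound 2 with one change: methoxy in place of hydrogen on an aromatic carbon. Among the compounds with values here, no measured pair isolates this change. A modest lowering of the number is expected in this assay, because compound 1, which also carries the methoxy group, gives 192 uM. The expected step is a 1.6-fold lower number from compound 2 to compound 3 (0.21 log units; within the scatter). For compound 3 the estimate in this assay is 250 uM, with a range from 120 uM to 520 uM.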

Compound 3, concentration for growth inhibition (reported as GI): 377 uM
For compound 3 the middle estimate is 1.5-fold (0.18 log units) below the measured one; low and high end bracket the measured number.
By their numbers in this assay, from the lowest: compounds 1, 3 and 2 (each within the scatter of the next, the first and the last beyond it).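

Within the data shown here, the first pair to isolate methoxy in place of hydrogen on an aromatic carbon, para to a group of 9 heavy atoms, reads in this assay as a 1.1-fold lower number from compound 2 to compound 3 (0.04 log units; within the scatter). Among these compounds, on the core of compound 2, this change therefore produces no step that can be told apart from repeat measurements, so this pair gives no sign that the position responds to methoxy. Nothing on hand gives a reason for the size of this step.

The compounds shown carry only hydrogen or methoxy at this place, so the response to an amine, a hydroxyl or a carboxylic acid there remains open. Also open, from the compounds shown here alone, is whether methoxy on another carbon of the same aromatic ring would give a step beyond the scatter.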